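Acetamido to Cyclobutylmethoxy on a Shared Core

The source may hold more compounds than are shown below. What is called first, only, known or untested is meant among the compounds shown, and "the series" means these compounds.

Compound 1 `CC(=O)Nc1ccc(-c2c(C#N)c(N)nc(SCC(N)=O)c2C#N)cc1` gives 17% in an assay on CHO cells for displacement of a labelled ligand from adenosine receptor A1 (Homo sapiens), read by scintillation counting, with a stated time of 90 min, tested at 1 uM (on this read-out higher numbers stand for more inhibition at the one concentration tested (going by the name of the read-out) and lower numbers for less inhibition), the second highest of three numbers, yet within the scatter of compound 3 `CNC(=O)CSc1nc(N)c(C#N)c(-c2ccc(OCC3CC3)cc2)c1C#N` at 14% and of compound 2 `N#Cc1c(N)nc(SCc2nc3ccccc3[nH]2)c(C#N)c1-c1ccc(OCC2CC2)cc1` at 21%. For the measured compounds named here, the one measured step, a number 7 percentage points lower from compound 2 to compound 3 (within the scatter), alters the group on a saturated chain carbon bound to a sulfur and so does not touch the aromatic position changed here. Compound 4 `N#Cc1c(N)nc(SCC(N)=O)c(C#N)c1-c1ccc(OCC2CCC2)cc1` differs from compound 1 by cyclobutylmethoxy in place of acetamido on an aromatic carbon. Going by the values given here, no measured step covers this change, and all three measured numbers sit within the scatter of one another, so no step beyond the scatter is expected. For compound 4 the value in this assay is estimated at 18%, from 5% to 35%. That estimate means an expected a number 1 percentage points higher from compound 1 to compound 4 (within the scatter).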

Compound 4, a percentage reported as inhibition, at one concentration (the size of the read-out at that concentration, not a potency): 1%
For compound 4 the middle estimate is 17 percentage points above the measured one; measured number below the stated range.
By their numbers in this assay, from the lowest: compound 4; then compounds 3, 1 and 2 (each within the scatter of the next).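

In this assay, cyclobutylmethoxy in place of acetamido on an aromatic carbon gives a number 16 percentage points lower from compound 1 to compound 4 (beyond the scatter), the only step shown that lies beyond the scatter. For the compounds shown here, this aromatic position, para to a large group, therefore affects the read-out, which the earlier compounds could not show, as their one step changed a group on the sulfur-bound chain carbon. No available evidence accounts for this drop.

A single exchange cannot separate the loss of acetamido from the arrival of cyclobutylmethoxy. On these data alone, it remains open whether a methoxy group or an amine on that aromatic carbon would give a number closer to that of compound 1 or compound 4.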